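The source may report more compounds than this note shows. Statements on the series, on what has been measured and on what is new or still open speak of the compounds shown alone.

Two compounds share the carbamate-bearing core seen in compound 1 `CCCCCCCCCCCCCCC(NC(=O)OC(C)(C)C)C(=O)O` and compound 2 `CCCCCCCCCCCCCCC(CN)NC(=O)OC(C)(C)C`. In an ADME assay on cells (Splenocyte, Mus musculus, strain BALB/c) for cytotoxicity, read by MTT assay, tested at 1 ug/mL (a lower number here means a weaker effect, a higher number a stronger effect of the compound at the concentration tested), compound 1 is recorded as "not determined" (no result reported). In this assay, among the measured compounds shown here, compound 2 gives 4.2%, the only number in the set, so it stands alone with nothing measured to rank it against. Compound 3 `CCCCCCCCCCCCCCC(CN(CC)CC)NC(=O)OC(C)(C)C` is the next member, not yet measured. It differs from compound 2 in one place: diethylamino in place of amino on a saturated chain carbon, two bonds along the chain from an amide-type nitrogen. For the measured compounds named here, with no measured step in this assay to lean on, the step from compound 2 to compound 3 is expected to be small, in either direction or none beyond the scatter. The low reading of compound 2, 4.2%, leaves little room downward. Compound 3 is therefore expected to read about 6% in this assay, within a range from 0% to 16%. The expected step is a number 1.8 percentage points higher from compound 2 to compound 3 (within the scatter), within the scatter.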

Compound 3, a percentage reported as activity, at one concentration (the size of the read-out at that concentration, not a potency): 6.5%
For compound 3 the middle estimate is 0.5 percentage points below the measured one, and the stated range covers the measured number.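

In this assay, among the compounds shown here, diethylamino in place of amino on a saturated chain carbon, two bonds along the chain from an amide-type nitrogen, gives a number 2.3 percentage points higher from compound 2 to compound 3 (within the scatter) as the first measured step at this position. At the one concentration tested, diethylamino, with 5 heavy atoms and 0 hydrogen-bond donors, and amino, with 1 heavy atom and 1 hydrogen-bond donor, cannot be told apart in this read-out. No measurement in hand offers an explanation for this result.

On these data alone, whether a hydroxyl group or a carboxylic acid at this place would read differently remains open, as does the effect of a shorter alkyl chain on the shared core. As far as these compounds go, the reading at higher concentrations also remains open, so the comparison of amino and diethylamino holds only for the concentration tested.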